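This account rests on a few compounds, and the source may have more. Where it says the series, first, only, none or still open, it means among the compounds named here.

Measured in a functional assay on CCRF-CEM cells (Homo sapiens) for antiproliferative activity, read by cell counting, with a stated time of 2 days; on this read-out higher numbers stand for weaker inhibition and lower numbers for stronger inhibition:
- compound 1 `CCN(CC)c1nc(N)c(C(=O)c2cc(OC)c(OC)c(OC)c2)s1`: 78000 nM
- compound 2 `COc1cc(C(=O)c2sc(N(C)Cc3ccccc3)nc2N)cc(OC)c1OC`: > 200000 nM (a limit)
- compound 3 `COc1ccc(C(=O)c2sc(N3CCCC3)nc2N)cc1`: > 200000 nM (a limit)

Compound 3 has no number, only the limit > 200000 nM. That limit is shared across the set, as the limit of > 200000 nM in this assay, at which 2 of the 3 values shown sit, shows.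

Compound 4 `Nc1nc(N2CCCC2)sc1C(=O)c1ccccc1` departs from compound 3 by one change, hydrogen in place of methoxy on an aromatic carbon, para to a large group: hydrogen in place of methoxy on an aromatic carbon.

Going by the values given here, only one measured step exists, an at least 2.5-fold higher number from compound 1 to compound 2 (0.40 log units; beyond the scatter). It is at least modest, but it concerns the amino substituent, not the methoxy, so it offers no direct guide to the size of this change. Among the compounds with values here, with no step measured at this place, no shift beyond the scatter is expected in this assay, and no direction can be assigned. The expected outcome is a number no higher from compound 3 to compound 4 (the limit leaves the size open). Compound 4 is expected to stay weak, most likely reported only as a limit. For compound 4 the estimated value is 200000 nM, with an expected range of 100000 nM to 400000 nM.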

Compound 4, half-maximal inhibitory concentration: > 200000 nM
Compound 4: only a limit was reported (the forecaster's own chance of this, stated with the estimate: 85%); the middle value lies on the limit itself.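

In this assay compound 3 and compound 4 are both reported only as limits, and the step between them cannot be read: the limit of > 200000 nM in this assay, at which 3 of the 4 values shown sit.

The compounds shown leave open whether hydrogen in place of methoxy on an aromatic carbon changes antiproliferative activity at all.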